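Hydrogen for chloro: what becomes of compound 3?

A few compounds are considered here, and "the series" means these few. Any claim that something is new, unique, unknown or untested is made for them only; others in the source may bear on it.

Compound 1 `Nc1cccn2cc(Cc3ccc(F)cc3)c(=O)nc12` gives > 1000000 nM as a limit
Compound 2 `O=c1nc2ccccn2cc1Cc1ccc(F)cc1C(F)(F)F` gives > 1000000 nM as a limit
Compound 3 `O=c1nc2ccc(Cl)cn2cc1Cc1ccc(F)cc1` gives 98300 nM as a number

All three results come from a functional assay on A549 cells (Homo sapiens) for cytotoxicity, read by MTT assay, with a stated time of 24 h (on this read-out lower numbers stand for stronger inhibition and higher numbers for weaker inhibition), and share one scale. Compound 3 is the only one of the three with an actual number, 98300 nM in this assay for this compound. Compound 1 gives > 1000000 nM and this is a limit, not a number. Compound 2 gives > 1000000 nM and this too is a limit.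

Compound 4 `O=c1nc2ccccn2cc1Cc1ccc(F)cc1` is compound 3 with hydrogen in place of chloro on an aromatic carbon and is otherwise unchanged. For the measured compounds named here, no pair of measured compounds differs by this change alone, so its size has not been seen directly. Going by the values given here, compound 3 is also the only measured compound that carries chloro, and its 98300 nM is the only number so far. On that thin basis, weaker inhibition is expected, meaning a higher number in this assay and a shift larger than the usual scatter. The expected step of a 3.6-fold higher number from compound 3 to compound 4 (0.55 log units; beyond the scatter) is an estimate resting on very few compounds. For compound 4 the estimate is 350000 nM with an expected range from 100000 nM to 1000000 nM and a real chance of only a limit.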

Compound 4, half-maximal inhibitory concentration: > 1000000 nM
Compound 4: a limit, no number; the forecaster's own chance of this, stated with the estimate: 40%; at least 2.8-fold (0.45 log units) between middle value and limit.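

In this assay, placing hydrogen in place of chloro on this aromatic carbon, two atoms from the ring nitrogen, gives an at least 10-fold higher number from compound 3 to compound 4 (1.00 log units; beyond the scatter). For the compounds shown here, this is the first pair of compounds that differs by this change alone, and it ties the only real number in the set directly to the chloro group; the size of the step is a minimum, since compound 4 has only a limit and no number of its own. The steps between the other compounds cannot be read, as those compounds share a single limit: the limit of > 1000000 nM in this assay, at which 3 of the 4 values shown sit.

On these data alone, only chloro and hydrogen can be compared at this position, so it remains open whether a bromo, methyl or methoxy group in the same place would also give a readable number, and whether any would go lower than compound 3. As far as these compounds go, it is also open how far past the limit compound 4 truly lies, so the full size of the chloro step remains unknown.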